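Working notes: 4-chlorophenyl in place of 2-hydroxyphenyl

The compounds below may be only part of what the source reports. "The series", "measured", "known", "first", "only" and "open" are said of these compounds alone.

Compound 1 `O=C(CO[N+](=O)[O-])NNC(=O)c1ccc(-n2[nH]c(=O)cc2-c2ccccc2O)cc1` carries a 2-hydroxyphenyl group, and in a functional assay on the whole organism (strain Wistar) for inhibition, with Rattus norvegicus as the target, read by paw edema, with a stated time of 1 h, at a dose of 6 mg/kg by the oral route (a lower number here means less inhibition, a higher number more inhibition at the dose given (going by the name of the read-out)), compound 1 gives 23%. Compound 2 `O=C(CO[N+](=O)[O-])NNC(=O)c1ccc(-n2[nH]c(=O)cc2-c2ccc(Cl)cc2)cc1` differs from it in a single place: 4-chlorophenyl in place of 2-hydroxyphenyl on an aromatic carbon. In this assay compound 2 gives 5.88%, and the measured step is a number 17.1 percentage points lower from compound 1 to compound 2 (beyond the scatter).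

Compound 3 `CCOC(=O)c1c(-c2ccccc2O)n(-c2ccc(C(=O)NNC(=O)CO[N+](=O)[O-])cc2)[nH]c1=O` rests on a core that is not the same as that of compound 1; the difference between the two cores is ethoxycarbonyl in place of hydrogen on an aromatic carbon. In this assay compound 3 gives 27.8%, and the step is a number 4.8 percentage points higher from compound 1 to compound 3 (within the scatter), so the two cores are not separated by this measurement. Compound 3 holds the highest of the three numbers, but its gap to compound 1 is within the scatter, so no order between them is claimed.

Compound 4 `CCOC(=O)c1c(-c2ccc(Cl)cc2)n(-c2ccc(C(=O)NNC(=O)CO[N+](=O)[O-])cc2)[nH]c1=O` is not yet measured in this assay. It stands to compound 3 as compound 2 stands to compound 1: 4-chlorophenyl in place of 2-hydroxyphenyl on an aromatic carbon. The place is not described in the same words, since in compound 3 the aromatic carbon is also next to the ring atom that bears an ethoxycarbonyl group (5 heavy atoms); the change is therefore the same kind of change, not the same change. Among the compounds here it occurs twice, with one measured step.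

Among the compounds with values here, the expected step is a number 16.8 percentage points lower from compound 3 to compound 4 (beyond the scatter), resting on the single measured step of this kind, a number 17.1 percentage points lower from compound 1 to compound 2 (beyond the scatter), widened for the altered surroundings. For compound 4 the estimate in this assay is 11%, expected to lie between 2% and 22%.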

Compound 4, a percentage reported as inhibition, in the whole organism at one dose (the size of the read-out at that dose, not a potency): 3.2%
Compound 4: middle estimate off by 7.8 percentage points, on the high side; the range from low to high includes it.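

In this assay, replacing 2-hydroxyphenyl with 4-chlorophenyl on the core bearing ethoxycarbonyl gives a number 24.6 percentage points lower from compound 3 to compound 4 (beyond the scatter), and this agrees with the step on the core of compound 1: the same change on two cores in this assay, a number 17.1 percentage points lower (beyond the scatter) from compound 1 to compound 2 and a number 24.6 percentage points lower (beyond the scatter) from compound 3 to compound 4, 7.5 percentage points apart, within the scatter of two such steps. Adding ethoxycarbonyl with 4-chlorophenyl in place gives a number 2.7 percentage points lower from compound 2 to compound 4 (within the scatter), and here too the two cores behave alike: the same change on two cores in this assay, a number 4.8 percentage points higher (within the scatter) from compound 1 to compound 3 and a number 2.7 percentage points lower (within the scatter) from compound 2 to compound 4, 7.5 percentage points apart, within the scatter of two such steps. Across these four compounds, the 4-chlorophenyl change therefore carries from one core to the other in direction and, within the scatter, in size, while the ethoxycarbonyl change gives no step beyond the scatter on either side; however, this rests on only two pairs at a single oral dose and a single stated time, and it identifies no cause for the lower numbers or any wider rule for the series.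

On these data alone, it remains open how much of the step comes from losing 2-hydroxyphenyl and how much from gaining 4-chlorophenyl, a question that a plain phenyl or a 4-methoxyphenyl group on the same aromatic carbon would address. Also open, as far as these compounds go, is how either core would respond to a carboxylic acid or an amide in place of ethoxycarbonyl.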